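From 4-(trifluoromethyl)phenyl to 2-nitrophenyl on a shared core

This account rests on a few compounds, and the source may have more. Where it says the series, first, only, none or still open, it means among the compounds named here.

In a functional assay with Homo sapiens as the target (on this read-out higher numbers stand for weaker inhibition and lower numbers for stronger inhibition), compound 1 (`CC(C)[C@H](NC(=O)COc1cccc2ccccc12)C(=O)N[C@@H](CC(=O)O)C(=O)COc1ccccc1`) gives 11200 nM while compound 2 (`CC(C)[C@H](NC(=O)COc1cccc2ccccc12)C(=O)N[C@@H](CC(=O)O)C(=O)COc1ccccc1C(F)(F)F`) gives 17300 nM and compound 3 (`CC(C)[C@H](NC(=O)COc1cccc2ccccc12)C(=O)N[C@@H](CC(=O)O)C(=O)COc1ccc(C(F)(F)F)cc1`) gives 12300 nM as its read-out. Compound 3 therefore stands within the scatter of both other compounds, and the three cannot be ranked.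

Compound 4 (`CC(C)[C@H](NC(=O)COc1cccc2ccccc12)C(=O)N[C@@H](CC(=O)O)C(=O)COc1ccccc1[N+](=O)[O-]`) carries 2-nitrophenyl in place of 4-(trifluoromethyl)phenyl on an oxygen on a saturated carbon. Among the measured compounds shown here, no measured compound holds a nitro group, so the data offer no direct precedent for this exchange. The nearest evidence comes from three steps on the same group. Trifluoromethyl in place of hydrogen on an aromatic carbon gave a 1.5-fold higher number from compound 1 to compound 2 (0.19 log units; within the scatter) and also a 1.1-fold higher number from compound 1 to compound 3 (0.04 log units; within the scatter) in the two cases measured. The exchange between the two trifluoromethyl-bearing phenyl groups gave a 1.4-fold lower number from compound 2 to compound 3 (0.15 log units; within the scatter) as its result. All three steps stay within the scatter, so no step beyond the scatter is expected in this assay for this change, and no direction is favoured. The step expected is a 1.1-fold higher number from compound 3 to compound 4 (0.02 log units; within the scatter) on this estimate. Compound 4 is estimated at 13000 nM (expected range 6500 nM to 26000 nM).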

Compound 4, half-maximal inhibitory concentration: 27700 nM
Estimate against measurement, compound 4: 2.1-fold (0.33 log units) below, and the stated range ends below it.
By their numbers in this assay, from the lowest: compounds 1, 3, 2 and 4 (each within the scatter of the next, the first and the last beyond it).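

In this assay, among the compounds shown here, 2-nitrophenyl on this oxygen yields the first steps at this position that lie beyond the scatter, both modest (a 2.3-fold higher number from compound 3 to compound 4 (0.35 log units; beyond the scatter); a 2.5-fold higher number from compound 1 to compound 4 (0.39 log units; beyond the scatter)), whereas every step among the earlier compounds stayed within it. The change does not separate compound 4 from every earlier compound, however: nitro in place of trifluoromethyl leaves the step within the scatter (a 1.6-fold higher number from compound 2 to compound 4 (0.20 log units; within the scatter)), so 2-nitrophenyl and 2-(trifluoromethyl)phenyl cannot be told apart in this read-out, and the series now shows a difference only between its two ends. No measurement available here bears on what lies behind this difference.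

The compounds shown leave open whether 4-nitrophenyl on this oxygen would read like compound 3 or like compound 4, so the contribution of the nitro group cannot yet be separated from that of its place on the ring. They also leave open whether an amine or a carboxylic acid at that same place on the phenyl ring would keep the number close to that of compound 1 or move it further.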